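Swapping the Cyclobutyl Amide for an Oxolane

The source may hold more compounds than are shown below. What is called first, only, known or untested is meant among the compounds shown, and "the series" means these compounds.

Compound 1 `CCn1c(-c2ccc(C(F)(F)F)nc2)nc2c(O[C@H]3CCN(C(=O)[C@H]4C[C@@H](OC)C4)C3)ncnc21` and compound 2 `CCn1c(-c2ccc(C(F)(F)F)nc2)nc2c(O[C@H]3CCN(C(=O)C4CCOC4)C3)ncnc21` share a core and differ in one place: oxolan-3-yl in place of 3-methoxycyclobutyl on a carbonyl carbon. In an ADME assay (Rattus norvegicus, strain Wistar Han) for pharmacokinetics (a higher number here means that more of the compound sits outside the plasma, a lower number that more of the compound stays in the plasma), compound 1 gives 1.3 L/kg, while compound 2 gives 3.6 L/kg, so that this single change made a step of a 2.8-fold higher number from compound 1 to compound 2 (0.44 log units; beyond the scatter).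

Compound 3 `CCn1c(-c2cnc(C)nc2)nc2c(N[C@H]3CCN(C(=O)[C@H]4C[C@@H](OC)C4)C3)ncnc21` belongs to a second series; how its core differs from the core of compound 1 is not broken down here. In this assay compound 3 gives 4.1 L/kg, which stands within the scatter of compound 2 and beyond it from compound 1.

Compound 4 `CCn1c(-c2cnc(C)nc2)nc2c(N[C@H]3CCN(C(=O)C4CCOC4)C3)ncnc21` is the member of the second series that carries the same change, (oxolan-3-yl in place of 3-methoxycyclobutyl on a carbonyl carbon). The place is the same in both series, a carbonyl carbon whose other neighbour is an amide-type nitrogen in a ring, so this is the same change seen from compound 1 to compound 2.

For the measured compounds named here, only one measured example of the change exists, and compound 3 already sits at the high end of the three numbers, so the step is expected to be in the same direction but not counted on in full size: for compound 4 a step of a 2.0-fold higher number from compound 3 to compound 4 (0.29 log units; within the scatter) is expected, resting on the measured step from compound 1 to compound 2, a 2.8-fold higher number from compound 1 to compound 2 (0.44 log units; beyond the scatter). Compound 4 is therefore estimated at 8 L/kg, with a likely range from 4 L/kg to 16 L/kg.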

Compound 4, volume of distribution: 2.3 L/kg
For compound 4 the middle estimate is 3.5-fold (0.54 log units) above the measured one, and the stated range ends above it.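

On the second core, oxolan-3-yl in place of 3-methoxycyclobutyl gives a 1.8-fold lower number from compound 3 to compound 4 (0.25 log units; within the scatter) in this assay, a step that does not stand clear of repeat measurements. The higher number seen on the first core therefore did not carry over to the second, and the two readings of the same change disagree: the same change on two cores in this assay, a 2.8-fold higher number (0.44 log units; beyond the scatter) from compound 1 to compound 2 and a 1.8-fold lower number (0.25 log units; within the scatter) from compound 3 to compound 4, 4.9-fold (0.69 log units) apart, beyond the scatter of two such steps. With a single pair on each core, this shows that a step measured on one core could not be carried to the other in this series, but it does not show which difference between the cores is responsible, nor what the change would do on any further core.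

The compounds shown leave open whether the linking oxygen of compound 1 and compound 2 or the linking nitrogen of compound 3 and compound 4 matters here, or instead the group at the other end of each core, since these differences are never seen alone. They also leave open how other groups on the same carbonyl carbon, such as a plain cyclobutyl, an oxetan-3-yl or a dimethylamino group, would read in this assay on either core.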